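The source may report more compounds than this note shows. Statements on the series, on what has been measured and on what is new or still open speak of the compounds shown alone.

The measured compounds are:
compound 1, `COc1cc(-c2nnc3n2NC(c2ccco2)C(C(=O)c2ccco2)S3)cc(OC)c1OC`, which in a functional assay on PC-3 cells (Homo sapiens) for cytotoxicity, read by MTT assay, with a stated time of 48 h (on this read-out lower numbers stand for stronger inhibition and higher numbers for weaker inhibition), gives 58300 nM;
compound 2, `COc1cc(-c2nnc3n2NC(c2ccco2)C(C(=O)C2CC2)S3)cc(OC)c1OC`, which in this assay gives 95200 nM;
compound 3, `COc1cc(-c2nnc3n2NC(c2ccco2)C(C(=O)c2ccc(C(F)(F)F)cc2)S3)cc(OC)c1OC`, which in this assay gives 77500 nM.

Compound 2 stands at the highest of the three numbers, yet none of the three can be told apart from the others, since each pairing stays within the scatter.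

Compound 4, `COc1cc(-c2nnc3n2NC(c2ccco2)C(C(=O)c2ccccc2)S3)cc(OC)c1OC`, has not been measured. It differs from compound 2 by phenyl in place of cyclopropyl on a carbonyl carbon; cut one bond further out, the change reads cyclopropylcarbonyl to benzoyl. Three steps already vary the group on this carbonyl carbon, and all of them are small: a 1.6-fold higher number from compound 1 to compound 2 (0.21 log units; within the scatter), a 1.3-fold higher number from compound 1 to compound 3 (0.12 log units; within the scatter) and a 1.2-fold lower number from compound 2 to compound 3 (0.09 log units; within the scatter). Furan-2-yl, cyclopropyl and 4-(trifluoromethyl)phenyl thus give numbers that are indistinguishable in this assay. With phenyl closest in kind to 4-(trifluoromethyl)phenyl, no step beyond the scatter is expected in either direction; the expected step is a 1.3-fold lower number from compound 2 to compound 4 (0.10 log units; within the scatter). Compound 4 is therefore estimated at 75000 nM, with a range from 40000 nM to 140000 nM.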

Compound 4, half-maximal inhibitory concentration: 64300 nM
Estimate against measurement, compound 4: 1.2-fold (0.07 log units) above; measured number inside the range.
By their numbers in this assay, from the lowest: compounds 1, 4, 3 and 2 (each within the scatter of the next).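

Placing phenyl on this carbonyl carbon in this assay gives a 1.5-fold lower number from compound 2 to compound 4 (0.17 log units; within the scatter) so a six-membered aromatic ring of carbon only reads the same here as a three-membered non-aromatic ring of carbon only. Phenyl in place of furan-2-yl gives a 1.1-fold higher number from compound 1 to compound 4 (0.04 log units; within the scatter) and hydrogen in place of trifluoromethyl on an aromatic carbon gives a 1.2-fold lower number from compound 3 to compound 4 (0.08 log units; within the scatter) so the trifluoromethyl on the phenyl also makes no readable difference. No evidence at hand speaks to what lies behind these results.

With all four groups within the scatter of one another, the compounds shown leave open whether any group on this carbonyl carbon can move the number beyond it. An amine, a carboxylic acid or a longer alkyl chain in this place remains an open case.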